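A nitro group moved within the phenyl ring of compound 3

The compounds below may be only part of what the source reports. "The series", "measured", "known", "first", "only" and "open" are said of these compounds alone.

Compound 1, `CC1=CC[C@@H]([C@@](C)(O)CCCC(C)(C)NC(=S)N/N=C\c2ccc(C)cc2)CC1`: 6750 nM
Compound 2, `COc1ccc(/C=N\NC(=S)NC(C)(C)CCC[C@](C)(O)[C@@H]2CC=C(C)CC2)cc1`: 7660 nM
Compound 3, `CC1=CC[C@@H]([C@@](C)(O)CCCC(C)(C)NC(=S)N/N=C\c2ccccc2[N+](=O)[O-])CC1`: 39900 nM

These three were measured in a functional assay on PCO3 cells (Homo sapiens) for cytotoxicity, read by sulforhodamine B assay; a higher number here means a weaker inhibitor of growth, a lower number a stronger inhibitor of growth. Compound 3 gives the highest number of the three, with a 5.9-fold higher number from compound 1 to compound 3 (0.77 log units; beyond the scatter) and a 5.2-fold higher number from compound 2 to compound 3 (0.72 log units; beyond the scatter). Compound 4, `CC1=CC[C@@H]([C@@](C)(O)CCCC(C)(C)NC(=S)N/N=C\c2ccc([N+](=O)[O-])cc2)CC1`, differs from compound 3 by 4-nitrophenyl in place of 2-nitrophenyl on a carbon with a double bond to nitrogen. For the measured compounds named here, no measured step moves a nitro group within the ring; the steps that bear on it are the two above, in which 2-nitrophenyl gave a higher number than the 4-methylphenyl of compound 1 or the 4-methoxyphenyl of compound 2. The 4-nitrophenyl of compound 4 matches those two groups in pattern, so a modest step down is expected, a 2.7-fold lower number from compound 3 to compound 4 (0.42 log units; beyond the scatter), though not a full return to their level. The estimate for compound 4 is 15000 nM, within 5000 nM to 45000 nM.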

Compound 4, concentration for 50% growth inhibition: 18100 nM
Compound 4: middle estimate off by 1.2-fold (0.08 log units), on the low side; the range from low to high includes it.
By their numbers in this assay, from the lowest: compounds 1 and 2 (each within the scatter of the next); then compound 4; then compound 3.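

In this assay, for the compounds shown here, this is the first step that keeps the nitro group and changes only its place in the group on a carbon with a double bond to nitrogen: 4-nitrophenyl in place of 2-nitrophenyl gives a modest shift (a 2.2-fold lower number from compound 3 to compound 4 (0.34 log units; beyond the scatter)). The 4-nitrophenyl group still does not match the earlier groups, with nitro in place of methoxy (a 2.4-fold higher number from compound 2 to compound 4 (0.37 log units; beyond the scatter)) and nitro in place of methyl (a 2.7-fold higher number from compound 1 to compound 4 (0.43 log units; beyond the scatter)), so both the nitro group and its place matter here. No evidence is available to explain these differences.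

The compounds shown leave open whether an amine or a carboxylic acid in place of the nitro group would stay closer to compound 1 and compound 2 or to compound 4.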